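From 4-(diethylamino)butyl to 3-(diethylamino)propyl in compound 1

A few compounds are considered here, and "the series" means these few. Any claim that something is new, unique, unknown or untested is made for them only; others in the source may bear on it.

In a functional assay on BCG823 cells (Homo sapiens) for antiproliferative activity, read by MTT assay, with a stated time of 48 h (a higher number here means a weaker inhibitor, a lower number a stronger inhibitor), compound 1 `CCN(CC)CCCCOc1c(OC)cc2oc(-c3ccccc3)cc(=O)c2c1O` gives 17400 nM as the middle of three values. Compound 3 `CN1CCN(CCCCOc2c(OCc3ccccc3)cc3oc(-c4ccccc4)cc(=O)c3c2O)CC1` lies lower at 7200 nM and compound 2 `CN1CCN(CCCCOc2c(O)cc3oc(-c4ccccc4)cc(=O)c3c2O)CC1` lies higher at 82900 nM and both gaps to compound 1 are beyond the scatter. Compound 4 `CCN(CC)CCCOc1c(OC)cc2oc(-c3ccccc3)cc(=O)c2c1O` has not yet been measured. It differs from compound 1 in the chain alone, with diethylamino in place of (diethylamino)methyl on a saturated chain carbon, three bonds along the chain from an oxygen on an aromatic ring as the change, which amounts to 3-(diethylamino)propyl in place of 4-(diethylamino)butyl.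

Among the measured compounds shown here, no measured step bears directly on this change. For the measured compounds named here, the one step available is a 12-fold lower number from compound 2 to compound 3 (1.06 log units; beyond the scatter) and it is large, yet it concerns benzyl in place of hydrogen on an oxygen on an aromatic ring and leaves the chain untouched, so it offers no guide to size or direction here. Going by the values given here, with no measured pair that differs in chain length, no step beyond the scatter is expected in this assay although the uncertainty remains wide. The expected step is a 1.1-fold higher number from compound 1 to compound 4 (0.06 log units; within the scatter) and it is estimated to stay within the scatter. Compound 4 is expected at 20000 nM with an estimated range from 8000 nM to 50000 nM on this read-out.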

Compound 4, half-maximal inhibitory concentration: 5700 nM
Compound 4: the middle estimate sits 3.5-fold (0.55 log units) above what was measured; measured number outside the range, below it.
By their numbers in this assay, from the lowest: compounds 4 and 3 (each within the scatter of the next); then compound 1; then compound 2.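

In this assay the step is a 3.1-fold lower number from compound 1 to compound 4 (0.48 log units; beyond the scatter) and is modest, with 3-(diethylamino)propyl in place of 4-(diethylamino)butyl and the rest of compound 1 unchanged. Among the compounds shown here, this pair gives the first direct reading of chain length, showing that this position is not indifferent to the loss of one chain carbon, whereas the earlier step concerned only benzyl in place of hydrogen on an oxygen on an aromatic ring and left the chain untouched. Nothing measured here accounts for the size or direction of this step.

A single pair cannot show whether the number would fall further with a shorter 2-(diethylamino)ethyl chain or rise again with a longer 5-(diethylamino)pentyl chain. It also leaves open whether the same shortening would give a step of similar size and direction with the amine carried by compound 2 and compound 3, with a dimethylamino group or a morpholine at the chain end, or with benzyloxy in place of the methoxy group of compound 1.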